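Aryl ether at the ring nitrogen-adjacent position: series notes

The compounds below may be only part of what the source reports. "The series", "measured", "known", "first", "only" and "open" are said of these compounds alone.

Measured so far:
compound 1 `Cc1cc(C)c2ncc(C(O)CC3CCCCN3)cc2c1` — 1.17
compound 2 `OC(CC1CCCCN1)c1ccnc2ccccc12` — 0.05

In a physicochemical assay for lipophilicity (a higher number here means a more lipophilic compound, a lower number a more polar compound), compound 2 gives the lower of the two values and compound 1 the higher, a gap beyond the scatter. Compound 3 `Cc1ccc(Oc2cc(C(O)CC3CCCCN3)c3ccccc3n2)cc1` is not yet measured. It differs from compound 2 by 4-methylphenoxy in place of hydrogen on an aromatic carbon. Going by the values given here, no measured step matches this change, so the size of this assay shift is estimated from the group that enters rather than read off. A clear rise is expected, well beyond the scatter. For compound 3 the estimate is 2.3, within 1.5 to 3.1, meaning an expected step of a number 2.25 log units higher from compound 2 to compound 3 (beyond the scatter).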

Compound 3, partition coefficient: 2.69
For compound 3 the middle estimate is 0.39 log units below the measured one; the measured number falls inside the stated range.
By their numbers in this assay, from the lowest: compound 2; then compound 1; then compound 3.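

In this assay, going by these compounds alone, 4-methylphenoxy on the aromatic carbon next to the ring nitrogen gives a number 2.64 log units higher from compound 2 to compound 3 (beyond the scatter), the first step that can be read at a single place. Compound 1 differs from compound 2 in more than one place and offers no such reading for this position. Nothing at hand bears on why the step has this size.

On these data alone, how much of the step belongs to the ring of the 4-methylphenoxy group, to its methyl or to its ether oxygen stays open. Phenoxy, methoxy or an amine on the same carbon would separate these contributions.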